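The compounds below may be only part of what the source reports. "The series", "measured", "known", "first", "only" and "open" are said of these compounds alone.

Working notes on the series. In a functional assay on NCI-H460 cells (Homo sapiens) for inhibition, read by MTT assay, with a stated time of 24 h, tested at 10 ug/mL (a lower number here means less inhibition of growth, a higher number more inhibition of growth at the concentration tested), compound 1 `O=C(CCCCC(S)CCS)Nc1ccccn1` is reported as "not active" (no number reported) with no number attached. Within the data shown here, compound 2 `O=C(CCCCC(S)CCS)Nc1ccc(Cl)cn1` gives 27.4% and this is the only number so far, so it cannot yet be ranked against a second value. Compound 3 `O=C(CCCCC(S)CCS)Nc1ccc(Br)cn1` still awaits measurement in this assay and differs from compound 2 at one place: bromo in place of chloro on an aromatic carbon with bromo in place of chloro on an aromatic carbon. Among the measured compounds shown here, no measured pair shows what this exchange does, so the expectation rests on compound 2 at 27.4% alone. The expected size of a number 0.6 percentage points higher from compound 2 to compound 3 (within the scatter) stays within the usual scatter, with no direction favoured. For compound 3 the estimated value is 28% with an expected range from 10% to 48% in this working figure.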

Compound 3, percent growth inhibition at one concentration: 39.3%
Compound 3: the middle estimate sits 11.3 percentage points below what was measured; low and high end bracket the measured number.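

In this assay the aromatic carbon two atoms from the ring nitrogen is sensitive to which halogen it carries: bromo in place of chloro gives a number 11.9 percentage points higher from compound 2 to compound 3 (beyond the scatter) and so the two halogens are not interchangeable at this position. Among these compounds, this is the first measured step at this place, and it is modest in size, with both halogen compounds giving a number while compound 1 is reported as "not active" (no number reported) in the same read-out. Nothing measured on these compounds accounts for the difference between bromo and chloro.

Going by these compounds, whether the rise continues to iodo, or whether a group of another kind such as methyl, methoxy or nitrile fits the same position, remains open. Also open, on these data alone, is how a shorter chain bearing the two thiol groups would read with bromo in place.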